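Changing the aniline ring on a shared kinase-like core

The source may hold more compounds than are shown below. What is called first, only, known or untested is meant among the compounds shown, and "the series" means these compounds.

Measured compounds in a functional assay on MCF7 cells (Homo sapiens) for cytotoxicity, read by sulforhodamine B assay, with a stated time of 72 h; a lower number here means a stronger inhibitor, a higher number a weaker inhibitor:
- compound 1 `CCS(=O)(=O)Nc1cc(-c2ccc3ncnc(Nc4cccc(F)c4)c3c2)cnc1OC` gives 8020 nM
- compound 2 `CCS(=O)(=O)Nc1cc(-c2ccc3ncnc(Nc4ccc(F)cc4)c3c2)cnc1OC` gives 6510 nM
- compound 3 `CCS(=O)(=O)Nc1cc(-c2ccc3ncnc(Nc4ccc(OC)c(Cl)c4)c3c2)cnc1OC` gives 3320 nM

All three compounds share the same core and differ only in the aromatic ring attached to the nitrogen on the core. Compound 3 has the lowest number of the three in this assay, but its lead over compound 2 is within the scatter, so it cannot be called the strongest on these data.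

Compound 4 `CCS(=O)(=O)Nc1cc(-c2ccc3ncnc(Nc4cccc(C(=O)OC)c4)c3c2)cnc1OC` continues this series: 3-(methoxycarbonyl)phenyl in place of 3-chloro-4-methoxyphenyl on a nitrogen on an aromatic ring. The measured steps all concern the same place. The step of a 1.2-fold lower number from compound 1 to compound 2 (0.09 log units; within the scatter), the step of a 2.4-fold lower number from compound 1 to compound 3 (0.38 log units; beyond the scatter) and the step of a 2.0-fold lower number from compound 2 to compound 3 (0.29 log units; within the scatter) show that swapping one substituted phenyl for another at this position has moved the number only slightly, with one step just beyond the scatter and two within it. The same size of effect is therefore expected here: a small shift, if any, and since compound 3 already has the lowest number, the expected direction is towards a somewhat higher number, a 1.5-fold higher number from compound 3 to compound 4 (0.18 log units; within the scatter). Compound 4 is therefore estimated at 5000 nM, with a range from 2000 nM to 14000 nM.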

Compound 4, half-maximal inhibitory concentration: 10100 nM
Compound 4: middle estimate off by 2.0-fold (0.31 log units), on the low side, and the stated range covers the measured number.
By their numbers in this assay, from the lowest: compounds 3, 2, 1 and 4 (each within the scatter of the next, the first and the last beyond it).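

In this assay, the 3-(methoxycarbonyl)phenyl group shows that this position can give a gap beyond the scatter in the upward direction from compound 3 (a 3.0-fold higher number from compound 3 to compound 4 (0.48 log units; beyond the scatter)), so a change of ring here is not always as small as the step between the two fluorophenyl compounds. The ester-bearing ring still does not separate from either fluorophenyl ring (a 1.6-fold higher number from compound 2 to compound 4 (0.19 log units; within the scatter); a 1.3-fold higher number from compound 1 to compound 4 (0.10 log units; within the scatter)), and the second of these steps is the direct swap of fluoro for methoxycarbonyl, which therefore leaves the number within the scatter. Across the four compounds, compound 3 is set apart from compound 1 and compound 4, while compound 2 cannot be separated from any of the other three, so the 3-chloro-4-methoxyphenyl ring is the only one with any claim to differ from the rest.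

No accompanying measurement gives a reason for the gap between compound 3 and compound 4. From the compounds shown here alone, it remains open whether the chloro or the methoxy group of compound 3 accounts for that gap, as a 3-chlorophenyl or a 4-methoxyphenyl ring would show, and whether a carboxylic acid or an amine in place of methoxycarbonyl would move the number at all.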